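Quinoxaline diamines: ether to thioether swap at the aryl position

The source may hold more compounds than are shown below. What is called first, only, known or untested is meant among the compounds shown, and "the series" means these compounds.

Within the data shown here, compound 1, structure `Nc1cc(N)c2nc(-c3ccccc3)c(Oc3ccc(Cl)c(Cl)c3)nc2c1`, is the only member of the series with a number rather than a limit in a functional assay on OVCAR-5 cells (Homo sapiens) for inhibition, read by sulforhodamine B assay, with a stated time of 48 h (a higher number here means a weaker inhibitor of growth, a lower number a stronger inhibitor of growth), where compound 1 gives 58900 nM. Compound 2, structure `CCOC(=O)[C@H](CCC(=O)O)NC(=O)c1ccc(Sc2nc3cc(N)cc(N)c3nc2-c2ccccc2)cc1`, returns in this assay only a limit, < 100000 nM. Compound 3, structure `CCOC(=O)[C@H](CCC(=O)O)NC(=O)c1ccc(Oc2nc3cc(N)cc(N)c3nc2-c2ccccc2)cc1`, likewise returns in this assay only a limit, < 100000 nM. Among the measured compounds shown here, the series thus rests on one number and on (the limit of < 100000 nM in this assay, at which 2 of the 3 values shown sit), so no step between measured compounds can be drawn.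

Compound 4, structure `Nc1cc(N)c2nc(-c3ccccc3)c(Sc3ccc(F)cc3)nc2c1`, differs from compound 1 in one place: (4-fluorophenyl)sulfanyl in place of 3,4-dichlorophenoxy on an aromatic carbon of the shared core. For the measured compounds named here, no measured pair in the set isolates an oxygen-to-sulfur exchange or a change in the halogen pattern of the pendant ring, so the size and direction of this step are open. The expectation is that the growth inhibition stays weak and that the step from compound 1 to compound 4 in this assay, a 1.0-fold higher number from compound 1 to compound 4 (0.01 log units; within the scatter), lies within the scatter. Compound 4 is therefore estimated at 60000 nM in this assay, with a range from 20000 nM to 150000 nM, and a real chance that only a limit is reported.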

Compound 4, concentration for total growth inhibition: 45700 nM
Beside the measured number, compound 4's estimate is 1.3-fold (0.12 log units) above it, and the stated range covers the measured number.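

In this assay, putting (4-fluorophenyl)sulfanyl in place of 3,4-dichlorophenoxy on the aromatic carbon next to the ring nitrogen and ortho to a phenyl group gives a 1.3-fold lower number from compound 1 to compound 4 (0.11 log units; within the scatter). Among these compounds, this is the first step that can be read, and it shows that this exchange at this position leaves the number within the scatter. Two things change together, the linking atom and the halogen pattern of the pendant ring, and this single step does not separate them, so neither change can be judged alone.

On these data alone, whether an amine, a carboxylic acid or a longer chain in place of the pendant aryl group on this carbon would move the number beyond the scatter stays open, as does the outcome of exchanging the linking atom with the pendant ring otherwise unchanged. Steps to compound 2 and compound 3 cannot be read, as both values are limits and not numbers: the limit of < 100000 nM in this assay, at which 2 of the 4 values shown sit.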